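Replacing the sulfur-linked bicyclic group of compound 2

This account rests on a few compounds, and the source may have more. Where it says the series, first, only, none or still open, it means among the compounds named here.

Measured compounds:
Compound 1, `OC(CSc1[nH]cnc2ncnc1-2)CN1CCN(C(c2ccc(Br)cc2)c2ccc(Br)cc2)CC1`: 64%
Compound 2, `OC(CSc1ncnc2[nH]cnc12)CN1CCN(C(c2ccc(F)cc2)c2ccc(F)cc2)CC1`: 189%
Compound 3, `COc1ccc(C(c2ccc(OC)cc2)N2CCN(CC(O)CSc3[nH]cnc4ncnc3-4)CC2)cc1`: 98%

In a functional assay on muscle tissue (Mustela putorius furo) (on this read-out higher numbers stand for larger maximal responses and lower numbers for smaller maximal responses), compound 2 stands highest of the three numbers. Its nearest neighbour is compound 3, whose number lies beyond the usual scatter below it, and compound 1 lies further still below it, also beyond the scatter. Among the compounds with values here, none of these three pairs differs in only one place, so no single step between measured compounds is known; the three values simply show that compound 2 sits well above the other two.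

Compound 4, `Nc1nc(SCC(O)CN2CCN(C(c3ccc(F)cc3)c3ccc(F)cc3)CC2)c2[nH]cnc2n1`, has not yet been measured in this assay. It differs from compound 2 by a group of 10 heavy atoms (5 carbon, 5 nitrogen; one five-membered aromatic ring with 2 hetero atoms, one six-membered aromatic ring with 2 hetero atoms) in place of a group of 9 heavy atoms (5 carbon, 4 nitrogen; one five-membered aromatic ring with 2 hetero atoms, one six-membered aromatic ring with 2 hetero atoms), on a sulfur. Within the data shown here, no measured pair shows what a change of this kind does here, so the expectation rests on compound 2 alone. The step is estimated at a number 39 percentage points lower from compound 2 to compound 4 (beyond the scatter), a moderate decrease that may well fall within the scatter. Compound 4 is expected to give 150%, with a range from 80% to 220%.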

Compound 4, largest response reached (reported as maximum), in percent of the reference or control that the assay uses: 74%
The estimate for compound 4 lay 76 percentage points above the measured number; measured number outside the range, below it.
By their numbers in this assay, from the lowest: compounds 1 and 4 (each within the scatter of the next); then compound 3; then compound 2.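

In this assay, within the data shown here, this is the first comparison in which only one place changes, and it shows that the response is sensitive to the group on the sulfur. Putting the group of 10 heavy atoms (5 carbon, 5 nitrogen) in place of the group of 9 heavy atoms (5 carbon, 4 nitrogen), with the rest of the molecule unchanged, gives a number 115 percentage points lower from compound 2 to compound 4 (beyond the scatter). Nothing measured here explains why this exchange has so large an effect.

This single step does not show whether the same exchange would have a similar effect in the bromo or methoxy compounds. It also leaves open how a methyl group, a hydroxyl group or a carboxylic acid would behave in place of the entering group's added atom.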